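The source may hold more compounds than are shown below. What is called first, only, known or untested is meant among the compounds shown, and "the series" means these compounds.

In a functional assay on MCF7 cells (Homo sapiens) for antiproliferative activity, read by MTT assay, with a stated time of 24 h, tested at 50 uM (on this read-out lower numbers stand for a stronger effect and higher numbers for a weaker effect at the one concentration tested), compound 2 `OC(CCn1nc2c(Br)c(Br)c(Br)c(Br)c2n1)c1ccc(F)cc1` gives 16%, the second highest of three numbers. Compound 1 `OC(CCn1nc2c(Br)c(Br)c(Br)c(Br)c2n1)c1cccc(Br)c1` gives 14%, and compound 3 `C[C@H](O)CCn1nc2c(Br)c(Br)c(Br)c(Br)c2n1` gives 105%. The change to compound 4 `CC(O)CCn1nc2c(Br)c(Br)c(Br)c(Br)c2n1` is methyl in place of 4-fluorophenyl on a saturated chain carbon bound to an oxygen on a saturated carbon and a saturated chain carbon. Among the measured compounds shown here, the single measured step, a number 2 percentage points higher from compound 1 to compound 2 (within the scatter), swaps one aromatic ring for another and does not bear on the loss of the ring itself. Yet compound 3, which carries methyl at that place with a stated configuration, shows a number far above that of compound 2 in this assay. Compound 4 is therefore expected to behave like compound 3, with a number 84 percentage points higher from compound 2 to compound 4 (beyond the scatter) as a rise beyond the scatter. The estimate for compound 4 is 100%, with a range from 85% to 115%.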

Compound 4, a percentage reported as activity, at one concentration (the size of the read-out at that concentration, not a potency): 90%
The estimate for compound 4 lay 10 percentage points above the measured number; the measured number falls inside the stated range.
By their numbers in this assay, from the lowest: compounds 1 and 2 (each within the scatter of the next); then compound 4; then compound 3.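

In this assay, the aromatic ring at this place proves to matter for the effect, which the ring-for-ring swap could not show: with methyl in its place the number rises sharply, a number 74 percentage points higher from compound 2 to compound 4 (beyond the scatter). The same holds for the other ring, a number 76 percentage points higher from compound 1 to compound 4 (beyond the scatter). The remaining step, a number 15 percentage points lower from compound 3 to compound 4 (beyond the scatter), cannot be read as an effect of configuration: the fact that one of compounds 3 and 4 is drawn with a defined configuration and the other without, at the place where they differ

As far as these compounds go, whether a cyclohexyl ring or a longer chain at this place would keep the stronger effect of compound 1 and compound 2 stays open.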